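The source may report more compounds than this note shows. Statements on the series, on what has been measured and on what is new or still open speak of the compounds shown alone.

Compound 1, `CC1=C(C(=O)OCC(C)C)C(c2ccoc2)NC(=S)N1`, gives 12% in an assay on membranes from CHO cells for displacement of a labelled ligand from adenosine receptor A1 (Homo sapiens), read by scintillation counting, with a stated time of 60 min, tested at 1 uM; a lower number here means less inhibition, a higher number more inhibition at the concentration tested (going by the name of the read-out). Compound 2, `CC1=C(C(=O)OC(C)(C)C)C(c2ccoc2)NC(=S)N1`, gives 18% in this assay. Compound 3, `CC1=C(C(=O)OCC(C)C)C(c2ccsc2)NC(=O)N1C`, gives 8% in this assay.

Compound 2 differs from compound 1 in one place, (tert-butyl in place of isobutyl on an oxygen next to a carbonyl group), and this change produced a number 6 percentage points higher from compound 1 to compound 2 (within the scatter). Compound 4, `CC1=C(C(=O)OC(C)(C)C)C(c2ccsc2)NC(=O)N1C`, has not yet been measured in this assay; it differs from compound 3 by the same change, (tert-butyl in place of isobutyl on an oxygen next to a carbonyl group). How the core of compound 3 differs from the core of compound 1 is not broken down here. Compound 4 is expected to stay close to compound 3, with a step of about a number 4 percentage points higher from compound 3 to compound 4 (within the scatter), because the same change earlier produced a number 6 percentage points higher from compound 1 to compound 2 (within the scatter). Compound 4 is therefore estimated at 12% in this assay, likely between 0% and 25%.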

Compound 4, a percentage reported as inhibition, at one concentration (the size of the read-out at that concentration, not a potency): 18%
The estimate for compound 4 lay 6 percentage points below the measured number; low and high end bracket the measured number.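

Putting tert-butyl in place of isobutyl on an oxygen next to a carbonyl group gave a number 10 percentage points higher from compound 3 to compound 4 (within the scatter) in this assay. Set beside the earlier step, the change reads alike on the two cores: the same change on two cores in this assay, a number 6 percentage points higher (within the scatter) from compound 1 to compound 2 and a number 10 percentage points higher (within the scatter) from compound 3 to compound 4, 4 percentage points apart, within the scatter of two such steps

Among these compounds, both steps lie within the scatter, so this shows only that the change behaves alike on these two cores, not that tert-butyl truly raises inhibition on either of them. The compounds shown leave open whether a longer chain or a chain carrying an amine in this place would move the number beyond the scatter. They also leave open how each difference between the two cores acts on its own.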